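Swapping trifluoromethyl for chloro on a diaryl urea

A few compounds are considered here, and "the series" means these few. Any claim that something is new, unique, unknown or untested is made for them only; others in the source may bear on it.

Two compounds share one core and differ only on the outer phenyl ring of the urea. Compound 1 `COc1cc2cc(Oc3ccc(NC(=O)Nc4cccc(C(F)(F)F)c4)cc3)c(C)nc2cc1OC` carries a trifluoromethyl group there; in a functional assay on LOX IMVI cells (Homo sapiens) for inhibition, read by sulforhodamine B assay, with a stated time of 48 h (a higher number here means that more compound is tolerated, a lower number that less compound is tolerated), compound 1 gives 18300 nM. Compound 2 `COc1cc2cc(Oc3ccc(NC(=O)Nc4ccc(Cl)c(C(F)(F)F)c4)cc3)c(C)nc2cc1OC` adds a chloro group to that ring, and in this assay compound 2 gives 11600 nM. The change a 1.6-fold lower number from compound 1 to compound 2 (0.20 log units; within the scatter) is a gap that falls within the scatter of repeated measurements, so the two numbers are best read as alike. Compound 2 therefore stands alongside compound 1, with no separation that can be trusted.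

Compound 3 `COc1cc2cc(Oc3ccc(NC(=O)Nc4ccc(Cl)c(Cl)c4)cc3)c(C)nc2cc1OC` makes the next change: chloro in place of trifluoromethyl on an aromatic carbon. Among the compounds with values here, no measured pair shows exactly this swap. Within the data shown here, the only step at hand, from compound 1 to compound 2, touched the same ring and stayed within the scatter, which gives no reason to expect a large move here. The step of a 1.1-fold lower number from compound 2 to compound 3 (0.02 log units; within the scatter) is expected to stay within the scatter. Compound 3 is estimated to give about 11000 nM, with a range from 4500 nM to 27000 nM.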

Compound 3, concentration lethal to 50% of the cells: 38200 nM
Compound 3: the middle estimate sits 3.5-fold (0.54 log units) below what was measured, outside the stated range (above it).
By their numbers in this assay, from the lowest: compounds 2 and 1 (each within the scatter of the next); then compound 3.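

Within the data shown here, the place on the ring that holds the trifluoromethyl group, ortho to a chloro group and meta to a large group, turns out not to be neutral in this assay: chloro in place of trifluoromethyl there gives a 3.3-fold higher number from compound 2 to compound 3 (0.52 log units; beyond the scatter), the first step in this short series that clears the usual scatter, and it moves towards more compound being tolerated. The 3,4-dichlorophenyl ring also stands apart from the 3-(trifluoromethyl)phenyl ring, with a 2.1-fold higher number from compound 1 to compound 3 (0.32 log units; beyond the scatter), so compound 3 has the highest number of the three, beyond the scatter from both compounds carrying trifluoromethyl, whereas adding a chloro group to the ring of compound 1 had produced no separation that could be trusted. No supporting measurement bears on this result, so the reason for the move remains unknown.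

With only trifluoromethyl and chloro seen at this place, the compounds shown leave open how a nitrile, a methoxy group or an amine there would read in this assay. Going by these compounds, it also remains open whether the same swap would give a similar step on a ring without the second chloro group.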